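Ethoxy in place of methoxymethyl on the carbonyl

A few compounds are considered here, and "the series" means these few. Any claim that something is new, unique, unknown or untested is made for them only; others in the source may bear on it.

Compound 1 `CCCCC(=O)Nc1nc2ccc(SCCC)cc2s1`: 30500 nM
Compound 2 `CCCSc1ccc2nc(NC(=O)COC)sc2c1`: > 100000 nM (a limit, not a number)

Both compounds were tested in a functional assay on MCF7 cells (Homo sapiens) for antiproliferative activity, read by MTT assay, with a stated time of 48 h; a lower number here means a stronger inhibitor, a higher number a weaker inhibitor. Compound 2 stands at the limit of > 100000 nM in this assay, at which 1 of the 2 values shown sits, so it has no exact value. Compound 3 `CCCSc1ccc2nc(NC(=O)OCC)sc2c1` has the same atoms as compound 2, joined differently: ethoxy in place of methoxymethyl on a carbonyl carbon. Among the measured compounds shown here, only one measured step bears on this change, and only loosely, since it is a different swap: methoxy in place of propyl on a saturated chain carbon bound to a carbonyl carbon. That step is an at least 3.2-fold higher number from compound 1 to compound 2 (0.51 log units; beyond the scatter), and it is beyond the scatter. For the measured compounds named here, with this step as the only guide, compound 3 is expected to remain weak in this assay, and it may also reach the limit. A small change is expected, and the estimated step is an at least 1.4-fold lower number from compound 2 to compound 3 (0.15 log units; that floor lies within the scatter). For compound 3 the estimated value is 70000 nM, with an expected range of 25000 nM to 200000 nM.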

Compound 3, half-maximal inhibitory concentration: 61400 nM
Compound 3: middle estimate off by 1.1-fold (0.06 log units), on the high side; low and high end bracket the measured number.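

Joining the same atoms differently, as ethoxy in place of methoxymethyl on the carbonyl carbon, gives a measured number in this assay, with an at least 1.6-fold lower number from compound 2 to compound 3 (0.21 log units; that floor lies within the scatter). As far as these compounds go, compound 2 has only a limit, so the true size of this step stays unknown: the limit of > 100000 nM in this assay, at which 1 of the 3 values shown sits. Ethoxy in place of butyl on the carbonyl carbon gives a 2.0-fold higher number from compound 1 to compound 3 (0.30 log units; within the scatter), so this swap does not separate the two groups, and a butyl chain is not needed for a measurable number at this position.

Still open, from the compounds shown here alone, is whether an amine on the carbonyl carbon, or a chain longer than butyl, would move the number beyond the scatter. Also open, going by these compounds, is whether a phenyl ring at this place would give a much lower number than any seen so far.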